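Trifluoromethyl for Ethyl on the Aryl Urea

The compounds below may be only part of what the source reports. "The series", "measured", "known", "first", "only" and "open" are said of these compounds alone.

Measured compounds:
compound 1 `Cc1cccc(NC(=O)N[C@@H](C)c2ccccc2)c1` gives 100%
compound 2 `CCc1ccccc1NC(=O)N[C@H](C)c1ccccc1` gives 92%
compound 3 `CCc1ccccc1NC(=O)N[C@@H](C)c1ccccc1` gives 95%

In an ADME assay on the whole organism with Oryza sativa as the target, tested at 10 uM (on this read-out lower numbers stand for a stronger effect and higher numbers for a weaker effect at the one concentration tested), compound 3 stands second highest of the three numbers; its nearest neighbour is compound 2 and its furthest compound 1, and both gaps lie within the scatter. Compound 4 `C[C@H](NC(=O)Nc1ccccc1C(F)(F)F)c1ccccc1` differs from compound 3 by trifluoromethyl in place of ethyl on an aromatic carbon. For the measured compounds named here, the only measured step, a number 3 percentage points higher from compound 2 to compound 3 (within the scatter), rests on the fact that compounds 2 and 3 differ only in the configuration as drawn and says nothing about a change of an aromatic substituent, so no measured step bears on this change. Compound 4 is therefore expected to show no step beyond the scatter, no change at the digits printed from compound 3 to compound 4 (within the scatter). For compound 4 the estimated value is 95%, with a range from 80% to 100%.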

Compound 4, a percentage reported as activity, at one concentration (the size of the read-out at that concentration, not a potency): 97%
For compound 4 the middle estimate is 2 percentage points below the measured one; low and high end bracket the measured number.
By their numbers in this assay, from the lowest: compounds 2, 3, 4 and 1 (each within the scatter of the next).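

Trifluoromethyl in place of ethyl on an aromatic carbon, ortho to a large group, gives a number 2 percentage points higher from compound 3 to compound 4 (within the scatter) in this assay. For the compounds shown here, this is the first view of a change of aromatic substituent, and at this place the read-out does not separate the two groups. Nothing in the evidence at hand accounts for this result. From the compounds shown here alone, whether an amine or a carboxylic acid on this aromatic carbon would move the number beyond the scatter remains open.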